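The compounds below may be only part of what the source reports. "The series", "measured", "known", "first", "only" and "open" are said of these compounds alone.

Of the compounds shown here, two have been measured in a functional assay on HEK293 cells for agonist activity at Motilin receptor (Homo sapiens), read by FLIPR; on this read-out higher numbers stand for an effect only at larger amounts of compound and lower numbers for an effect already at smaller amounts. Compound 1 `Cc1ccc(S(=O)(=O)NCC(=O)N(C)Cc2ccccc2-c2ccc(CN3C[C@@H](C)N[C@@H](C)C3)cc2)cc1` gives 20 nM, while compound 2 `C[C@@H]1CN(Cc2ccc(-c3ccccc3C(=O)N3CCC(Oc4ccc(F)cc4)CC3)cc2)C[C@H](C)N1` gives 63.1 nM, the higher of the two numbers, so compound 2 needs the larger amount to act; the gap between the two stands beyond the usual scatter of this assay. Compound 3 `C[C@@H]1CN(Cc2ccc(-c3ccccc3C(=O)N3CCC(NC(=O)c4ccc(F)cc4)CC3)cc2)C[C@H](C)N1` has not yet been measured. It differs from compound 2 in one place: ((4-fluorophenyl)carbonyl)amino in place of 4-fluorophenoxy on a saturated ring carbon. The fluorine-bearing aromatic ring thus remains, but it is now joined to the saturated ring through an amide rather than an ether oxygen. Within the data shown here, no measured pair shows what such a change does here, so only a rough expectation is possible. Relative to compound 2, the step expected for compound 3 is a 1.3-fold higher number from compound 2 to compound 3 (0.10 log units; within the scatter), a mild drift towards a higher number. The estimate for compound 3 in this assay is 80 nM, within a range from 20 nM to 320 nM.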

Compound 3, half-maximal effective concentration: > 10000 nM
Compound 3 was reported as a limit (the forecaster's own chance of this, stated with the estimate: 5%); middle value at least 120-fold (2.09 log units) from the limit.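

In this assay, replacing 4-fluorophenoxy with ((4-fluorophenyl)carbonyl)amino on this saturated ring carbon, three ring bonds from the ring nitrogen, gives an at least 150-fold higher number from compound 2 to compound 3 (2.19 log units; beyond the scatter). Among these compounds, the fluorine-bearing aromatic ring is present on both sides of this step, so the earlier compounds' tolerance of a large group does not extend to every link at this position: what joins that aromatic ring to the saturated ring matters greatly. The value of compound 3 is a limit of the assay, not a number: the limit of > 10000 nM in this assay, at which 1 of the 3 values shown sits.

The compounds shown leave open whether the amide hydrogen, the carbonyl or the longer link goes with this loss. A methyl group on the amide nitrogen or a plain methylene link to the aromatic ring would help to separate these possibilities.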